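Working notes: the step from compound 2 to compound 4

The compounds below may be only part of what the source reports. "The series", "measured", "known", "first", "only" and "open" are said of these compounds alone.

In a functional assay on MT4 cells (Homo sapiens) for cytotoxicity, read by CellTiter-Glo, with a stated time of 5 days (on this read-out higher numbers stand for an effect only at larger amounts of compound and lower numbers for an effect already at smaller amounts), compound 2 (`Cc1ccc(-c2c(C)noc2CO)cc1S(=O)(=O)NC1CCCC1`) gives 6820 nM and lies within the scatter of compound 1 (`CC(=O)NCc1onc(C)c1-c1ccc(C)c(S(=O)(=O)NC2CCCC2)c1`) at 4920 nM on the same read-out. Both numbers are well above that of compound 3 (`Cc1noc(C)c1-c1cc(S(=O)(=O)NC2CCCC2)c2cc(N3CCCC3)c(=O)[nH]c2c1`) at 140 nM in this series.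

Compound 4 (`Cc1ccc(-c2c(C)n[nH]c2C)cc1S(=O)(=O)NC1CCCC1`) carries 3,5-dimethyl-1H-pyrazol-4-yl in place of the group on the aromatic carbon of compound 2 (a group of 7 heavy atoms (5 carbon, 2 nitrogen; one five-membered aromatic ring with 2 hetero atoms) in place of a group of 8 heavy atoms (5 carbon, 1 nitrogen, 2 oxygen; one five-membered aromatic ring with 2 hetero atoms), on an aromatic carbon).

Going by the values given here, the only measured step in one place, a 1.4-fold higher number from compound 1 to compound 2 (0.14 log units; within the scatter), exchanges acetamido for hydroxy on a saturated chain carbon and stays within the scatter. It does not exchange the five-membered ring itself, so it bears on the change only indirectly. Among the compounds with values here, compound 3 differs from compound 2 in more than one place and offers no clean step. No shift beyond the scatter is therefore expected, and the estimated step is a 1.4-fold lower number from compound 2 to compound 4 (0.13 log units; within the scatter) with wide margins.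

In this assay the estimate for compound 4 is 5000 nM with an expected range of 1800 nM to 14000 nM around it.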

Compound 4, half-maximal effective concentration: 5420 nM
Compound 4: middle estimate off by 1.1-fold (0.04 log units), on the low side, within the range that was stated.
By their numbers in this assay, from the lowest: compound 3; then compounds 1, 4 and 2 (each within the scatter of the next).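

In this assay, replacing the whole five-membered ring unit on this aromatic carbon, para to a methyl group, gives a 1.3-fold lower number from compound 2 to compound 4 (0.10 log units; within the scatter). The earlier step altered only a substituent on a saturated chain carbon, whereas this one exchanges the ring itself for 3,5-dimethyl-1H-pyrazol-4-yl and still does not separate the two compounds on this read-out. At this position, then, the two ring groups compared here cannot be told apart, and a change of ring with two hetero atoms has not yet produced a shift beyond the scatter.

Going by these compounds, whether an amine or a carboxylic acid on this aromatic carbon in place of 3,5-dimethyl-1H-pyrazol-4-yl would shift the number beyond the scatter remains open. No supporting measurement is available to account for this result.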